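The compounds below may be only part of what the source reports. "The series", "measured", "known", "first", "only" and "open" are said of these compounds alone.

Measured so far in an ADME assay on MT2 cells (Homo sapiens) for inhibition; a higher number here means that more compound is tolerated, a lower number that less compound is tolerated:
- compound 1 `CCc1cc(F)c(Cc2cnc(Nc3ccc(C#N)c(Cl)c3)o2)c(F)c1`: 10000 nM
- compound 2 `CCC(C)c1cc(F)c(Cc2cnc(Nc3ccc(C#N)c(Cl)c3)o2)c(F)c1`: 40000 nM

For the measured compounds named here, compound 2 holds the higher of the two numbers in this assay; its only neighbour is compound 1, and the single measured step, a 4.0-fold higher number from compound 1 to compound 2 (0.60 log units; beyond the scatter), lies beyond the scatter. Compound 3 `CCOc1cc(F)c(Cc2cnc(Nc3ccc(C#N)c(Cl)c3)o2)c(F)c1` differs from compound 2 in one place: ethoxy in place of sec-butyl on an aromatic carbon. Going by the values given here, the one step in hand covers the same position of the shared core, where adding ethyl raised the number modestly. Ethoxy is nearer to the ethyl of compound 1 than to the sec-butyl of compound 2 in what it carries, so a step back toward compound 1 is expected, yet the oxygen is without precedent here, and the expectation is weak. Compound 3 is expected to show a 2.7-fold lower number from compound 2 to compound 3 (0.43 log units; beyond the scatter) in this assay, giving an estimated 15000 nM with a range of 5000 nM to 50000 nM.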

Compound 3, half-maximal cytotoxic concentration: 15000 nM
For compound 3 middle estimate and measured number coincide at the digits printed; measured number inside the range.
By their numbers in this assay, from the lowest: compounds 1 and 3 (each within the scatter of the next); then compound 2.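

In this assay, ethoxy in place of sec-butyl on this aromatic carbon gives a 2.7-fold lower number from compound 2 to compound 3 (0.43 log units; beyond the scatter) and so does not keep the number reached with sec-butyl. Ethoxy in place of ethyl gives a 1.5-fold higher number from compound 1 to compound 3 (0.18 log units; within the scatter) and leaves compound 1 and compound 3 not told apart, so among the three groups at this position only the sec-butyl of compound 2 stands out. No supporting data are at hand to explain this difference.

The compounds shown leave open whether branching or chain length accounts for the sec-butyl result, which n-butyl and isopropoxy on the same carbon would help to separate. They also leave open how an amine or a carboxylic acid at this position would read in this assay.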